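Fluorinating the benzyl group in an inactive pair

The source may report more compounds than this note shows. Statements on the series, on what has been measured and on what is new or still open speak of the compounds shown alone.

Measured so far:
compound 1, `CCCCCSc1nnc(COc2cc(C)c3c(C)cc(=O)oc3c2)o1`; in a functional assay on MCF7 cells (Homo sapiens) for antiproliferative activity, read by MTT assay, with a stated time of 24 h (a lower number here means a stronger inhibitor, a higher number a weaker inhibitor), compound 1 gives > 100000 nM, a limit of the assay.
compound 2, `Cc1cc(OCc2nnc(SCc3ccccc3)o2)cc2oc(=O)cc(C)c12`; in this assay compound 2 gives > 100000 nM, likewise a limit.

Compound 2 stands only at a limit in this assay; both values shown sit at that limit (the limit of > 100000 nM in this assay, at which 2 of the 2 values shown sit). The step that the two limits leave unreadable from compound 1 to compound 2 cannot be read from two limits. Compound 3 `Cc1cc(OCc2nnc(SCc3ccc(F)c(F)c3)o2)cc2oc(=O)cc(C)c12` differs from compound 2 by 3,4-difluorophenyl in place of phenyl on a saturated chain carbon bound to a sulfur. Among the measured compounds shown here, no measured step bears on this change in readable size, so compound 3 is expected to remain at the limit, with a step that the limit leaves unreadable from compound 2 to compound 3 of no readable size. The estimate for compound 3 is 150000 nM, with a range from 50000 nM to 500000 nM.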

Compound 3, half-maximal inhibitory concentration: 33300 nM
Estimate against measurement, compound 3: 4.5-fold (0.65 log units) above, and the stated range ends above it.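

In this assay, the position on a saturated chain carbon bound to a sulfur now gives a readable response: 3,4-difluorophenyl in place of phenyl gives an at least 3.0-fold lower number from compound 2 to compound 3 (0.47 log units; beyond the scatter). The same group in place of butyl gives an at least 3.0-fold lower number from compound 1 to compound 3 (0.47 log units; beyond the scatter). Both steps are bounds rather than sizes, with the true gaps possibly larger: the limit of > 100000 nM in this assay, at which 2 of the 3 values shown sit.

The compounds shown do not tell whether both fluorines are needed or a single fluorine would suffice. From the compounds shown here alone, how a chlorine or a methoxy group on the phenyl ring would compare also remains open.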